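This account rests on a few compounds, and the source may have more. Where it says the series, first, only, none or still open, it means among the compounds named here.

Measured in an ADME assay on HEK-293T cells (Homo sapiens) for cytotoxicity, read by MTT assay, with a stated time of 24 h; a lower number here means that less compound is tolerated, a higher number that more compound is tolerated:
- Compound 1 (`Cc1ccc(-c2nn(-c3ccccc3)cc2-c2nc3ccccc3n2S(=O)(=O)c2ccc(F)cc2)cc1`): 128000 nM
- Compound 2 (`Cc1ccc(-c2nn(-c3ccccc3)cc2-c2nc3ccccc3n2S(=O)(=O)c2ccc(C(F)(F)F)cc2)cc1`): 182000 nM
- Compound 3 (`COc1ccc(S(=O)(=O)n2c(-c3cn(-c4ccccc4)nc3-c3ccc(F)cc3)nc3ccccc32)cc1`): 37300 nM

Compound 3 stands lowest of the three, beyond the scatter from both others. Compound 4 (`O=S(=O)(c1ccc(Br)cc1)n1c(-c2cn(-c3ccccc3)nc2-c2ccc(F)cc2)nc2ccccc21`) differs from it by one change: bromo in place of methoxy on an aromatic carbon. Bromo replaces methoxy on an aromatic carbon. Among the compounds with values here, the only measured step at this place is a 1.4-fold higher number from compound 1 to compound 2 (0.15 log units; within the scatter), within the scatter, and it involves neither group. Compound 1 at 128000 nM and compound 2 at 182000 nM lack the methoxy, but they also differ from compound 3 elsewhere, so only a moderate rise is expected. The expected step is a 2.1-fold higher number from compound 3 to compound 4 (0.33 log units; beyond the scatter). The estimate for compound 4 is 80000 nM, with an expected range of 30000 nM to 200000 nM.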

Compound 4, half-maximal cytotoxic concentration: 239000 nM
Beside the measured number, compound 4's estimate is 3.0-fold (0.48 log units) below it; the whole stated range lies below it.
By their numbers in this assay, from the lowest: compound 3; then compounds 1, 2 and 4 (each within the scatter of the next).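

In this assay, a 6.4-fold higher number from compound 3 to compound 4 (0.81 log units; beyond the scatter) shows that a single change at this position can move the number beyond the scatter, which the earlier step here, a 1.4-fold higher number from compound 1 to compound 2 (0.15 log units; within the scatter), did not. The measurements at hand offer no reason for the size of this step.

From the compounds shown here alone, whether the rise comes from losing the methoxy or from gaining the bromo stays open. A hydrogen, a chloro or an amine at this place on the core of compound 3 would help to separate the two.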